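The compounds below may be only part of what the source reports. "The series", "measured", "known", "first", "only" and "open" are said of these compounds alone.

Two members of the shared core, both carrying the isobutyl chain on the thiophene and the imidazolylmethylphenyl substituent, have been measured in an assay on HEK293 cells for displacement of a labelled ligand from Type-2 angiotensin II receptor (Homo sapiens), read by scintillation counting, with a stated time of 240 min; on this read-out lower numbers stand for stronger inhibition and higher numbers for weaker inhibition. Compound 1 `CC(C)Cc1cc(-c2cccc(Cn3ccnc3)c2)c(S(=O)(=O)NC(=O)OC(C)C)s1` gives 160 nM. Compound 2 `CC(C)COC(=O)NS(=O)(=O)c1sc(CC(C)C)cc1-c1cccc(Cn2ccnc2)c1` gives 130 nM. Going by the values given here, the single measured step, a 1.2-fold lower number from compound 1 to compound 2 (0.09 log units; within the scatter), is within the scatter, so compound 2 stands as the lower of the two numbers without any real separation from compound 1.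

Compound 3 `CCCC(=O)NS(=O)(=O)c1sc(CC(C)C)cc1-c1cccc(Cn2ccnc2)c1` differs from compound 2 in one place: propyl in place of isobutoxy on a carbonyl carbon. This change is of a different kind from the measured one, which only altered the alkyl part on the carbonyl-bound oxygen; here the oxygen itself leaves and a propyl chain takes its place on the carbonyl carbon. Among the compounds with values here, no measured step therefore bears directly on it. With only a within-scatter step in hand, and a change that removes a hydrogen-bond acceptor, the estimate for compound 3 in this assay is placed near the two known values, leaning slightly toward a higher number, at 220 nM with a range of 80 nM to 600 nM, which means an expected step of a 1.7-fold higher number from compound 2 to compound 3 (0.23 log units; within the scatter).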

Compound 3, inhibition constant: 300 nM
Beside the measured number, compound 3's estimate is 1.4-fold (0.13 log units) below it, and the stated range covers the measured number.
By their numbers in this assay, from the lowest: compounds 2, 1 and 3 (each within the scatter of the next, the first and the last beyond it).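

In this assay, going by these compounds alone, changing the group on the carbonyl carbon itself, rather than only the alkyl part on the oxygen, gives the first step that lies beyond the scatter, with a 2.3-fold higher number from compound 2 to compound 3 (0.36 log units; beyond the scatter) as a modest shift when isobutoxy gives way to propyl. Within the data shown here, the same kind of change starting from isopropoxy gives a 1.9-fold higher number from compound 1 to compound 3 (0.27 log units; within the scatter) and stays within the scatter, so only one of the two comparisons separates the propyl compound from the compounds that keep the oxygen. Across these three compounds, then, replacing the oxygen-linked chain with propyl moves the number only a little, and no evidence is available to account for that shift.

The compounds shown do not separate the removal of the oxygen from the change in chain size, since isobutoxy and propyl differ in both. A pentyl chain or an amine on the same carbonyl carbon would be needed to tell how far this position follows the oxygen and how far it follows the length of the chain.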